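Swapping the Saturated Amine Ring Ahead of Measurement

The source may report more compounds than this note shows. Statements on the series, on what has been measured and on what is new or still open speak of the compounds shown alone.

Compound 1 `O=C1C(N2CCCC2)=NN(c2ccccc2)CN1c1ccccc1Cl` gives 44.3 ug/mL in a functional assay on HeLa cells (Homo sapiens) for cytotoxicity, with a stated time of 72 h; a lower number here means that less compound is tolerated, a higher number that more compound is tolerated.
Compound 3 `O=C1C(N2CCCCC2)=NN(c2ccccc2)CN1c1ccccc1Cl` gives 26 ug/mL in this assay.
Compound 2 `O=C1C(N2CCCCC2)=NN(c2ccc(Cl)cc2)CN1c1ccccc1Cl` reaches only a limit of > 50 ug/mL in this assay.

For the measured compounds named here, compound 2 therefore stands not at a number but at a limit; it is the single value sitting at the limit of > 50 ug/mL in this assay, at which 1 of the 3 values shown sits. Compound 4 `O=C1C(N2CCCC2)=NN(c2ccc(Cl)cc2)CN1c1ccccc1Cl` differs from compound 2 in one place: pyrrolidin-1-yl in place of piperidin-1-yl on a carbon with a double bond to nitrogen. Going by the values given here, of the measured steps, the one running from compound 1 to compound 3 is the same exchange in the opposite direction, and it moved little: a 1.7-fold lower number from compound 1 to compound 3 (0.23 log units; within the scatter). The other step, an at least 1.9-fold lower number from compound 2 to compound 3 (0.28 log units; that floor lies within the scatter), concerns a different group and speaks to the limit of compound 2 rather than to the ring swap. Given that the step of a 1.7-fold lower number from compound 1 to compound 3 (0.23 log units; within the scatter) lay within the scatter, compound 4 is expected to sit close to where compound 2 sits, most likely again at or beyond the limit. The expected step is a step that the limit leaves unreadable from compound 2 to compound 4. Compound 4 is thus estimated at 60 ug/mL, within a range from 35 ug/mL to 120 ug/mL.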

Compound 4, half-maximal cytotoxic concentration: > 50 ug/mL
Compound 4: a limit, no number; the forecaster's own chance of this, stated with the estimate: 65%; the middle value lies beyond the limit too.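

In this assay compound 4 stands at a limit, as compound 2 does, so with the 4-chlorophenyl group in place the swap of piperidin-1-yl for pyrrolidin-1-yl gives a step that cannot be read. With pyrrolidin-1-yl in place, the exchange of hydrogen for chloro can be read only as a floor: an at least 1.1-fold higher number from compound 1 to compound 4 (0.05 log units; that floor lies within the scatter). This chloro exchange now stands on two cores, and neither gives more than a floor within the scatter: the same change on two cores in this assay, an at least 1.9-fold lower number (0.28 log units; that floor lies within the scatter) from compound 2 to compound 3 and an at least 1.1-fold lower number (0.05 log units; that floor lies within the scatter) from compound 4 to compound 1; the limit leaves it open whether they differ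

Going by these compounds, how far compound 2 and compound 4 lie beyond their limits remains open, and with it the size of any effect of the chloro group: the limit of > 50 ug/mL in this assay, at which 2 of the 4 values shown sit. Also open is whether morpholin-4-yl or dimethylamino on this carbon would give a readable number in this assay.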